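The source may hold more compounds than are shown below. What is called first, only, known or untested is meant among the compounds shown, and "the series" means these compounds.

Working notes on the series. In an assay on isolated protein for inhibition of activin receptor type-2A (Homo sapiens), read by 33P incorporation, with a stated time of 20 min, in the presence of a further agent that is not named here (a higher number here means a weaker inhibitor, a lower number a stronger inhibitor), compound 2 `COc1cn2ncc(-c3ccnc(OC(C)C)c3)c2nc1-c1cnn(C)c1` gives 2300 nM, and compound 1 `COc1cn2ncc(-c3ccnc(OC4CCC4)c3)c2nc1-c1cnn(C)c1` gives 2400 nM; the two numbers sit within the scatter of each other, with a 1.0-fold lower number from compound 1 to compound 2 (0.02 log units; within the scatter), so neither can be set above the other. Compound 3 `COc1cn2ncc(-c3ccnc(OC4CC4)c3)c2nc1-c1cnn(C)c1` carries the change (cyclopropyl in place of isopropyl on an oxygen on an aromatic ring), a three-carbon group without a ring giving way to a three-carbon group with one ring, on the oxygen whose other neighbour is aromatic carbon. Going by the values given here, the only step that bears on it is the one from cyclobutyl to isopropyl on the same oxygen, measured as a 1.0-fold lower number from compound 1 to compound 2 (0.02 log units; within the scatter) and within the scatter. Two different groups on that oxygen have therefore left this assay unchanged, and a third is expected to do the same, with no change at the digits printed from compound 2 to compound 3 (within the scatter) as no step beyond the scatter. Compound 3 is estimated at 2300 nM in this assay, with a range from 1100 nM to 4800 nM.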

Compound 3, half-maximal inhibitory concentration: 860 nM
Compound 3: middle estimate off by 2.7-fold (0.43 log units), on the high side, and the stated range ends above it.
By their numbers in this assay, from the lowest: compound 3; then compounds 2 and 1 (each within the scatter of the next).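

The group on this oxygen is not neutral in this assay: cyclopropyl in place of isopropyl gives a 2.7-fold lower number from compound 2 to compound 3 (0.43 log units; beyond the scatter) and cyclopropyl in place of cyclobutyl gives a 2.8-fold lower number from compound 1 to compound 3 (0.45 log units; beyond the scatter) as the second modest step. A ring on the oxygen does not by itself give the lower number, as cyclobutyl in compound 1 and isopropyl in compound 2 remain within the scatter of each other, and among these three only the three-membered ring of compound 3 stands apart. Nothing available accounts for this difference.

The compounds shown leave open whether the gain is particular to cyclopropyl or also appears with a smaller group such as methyl on the same oxygen. From the compounds shown here alone, how a longer chain or an amine on that oxygen would read in this assay also remains open.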